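The compounds below may be only part of what the source reports. "The series", "measured", "known", "first", "only" and "open" are said of these compounds alone.

Of the compounds shown here, two from this series have been measured in an assay on isolated protein for inhibition of prostaglandin E2 receptor EP1 subtype (Homo sapiens); a higher number here means a weaker inhibitor, a lower number a stronger inhibitor. Compound 1, `CSc1ccc(OCc2ccc(F)cc2F)c(C2=C(c3cccc(C(=O)O)c3)CCC2)c1`, gives 15.9 nM. Compound 2, `CS(=O)(=O)c1ccc(OCc2ccc(F)cc2)c(C2=C(c3cccc(C(=O)O)c3)CCC2)c1`, gives 79.4 nM, the higher of the two numbers, and its gap to compound 1 lies beyond the scatter of the assay, so compound 2 is the weaker inhibitor of the pair. Compound 1 and compound 2 differ in more than one place, so no single step can be read from them.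

Compound 3, `CS(=O)(=O)c1ccc(OCc2ccc(F)cc2F)c(C2=C(c3cccc(C(=O)O)c3)CCC2)c1`, has not been measured. It differs from compound 2 in one place: fluoro in place of hydrogen on an aromatic carbon. With that change, compound 3 carries the same (2,4-difluorobenzyl)oxy group as compound 1 while keeping the rest of compound 2 unchanged. Nothing measured here isolates the effect of this fluoro group on its own. Compound 3 is therefore expected to land at a somewhat lower number than compound 2, a step of a 2.0-fold lower number from compound 2 to compound 3 (0.30 log units; within the scatter), but the direction is far from certain. The estimate for compound 3 in this assay is 40 nM, with a range from 15 nM to 120 nM.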

Compound 3, half-maximal inhibitory concentration: 15.9 nM
For compound 3 the middle estimate is 2.5-fold (0.40 log units) above the measured one, and the stated range covers the measured number.
By their numbers in this assay, from the lowest: compounds 1 and 3 (each within the scatter of the next); then compound 2.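

In this assay, adding a fluoro group on the aromatic carbon ortho to a large group, which turns 4-fluorobenzyl into 2,4-difluorobenzyl, gives a 5.0-fold lower number from compound 2 to compound 3 (0.70 log units; beyond the scatter). This shows that this one position on the ring matters in this series, something the earlier pair could not show, as its two members differ in more than one place. With the 2,4-difluorobenzyl group in place, methylsulfonyl in place of methylsulfanyl gives no change at the digits printed from compound 1 to compound 3 (within the scatter), so the assay sees no difference between these two sulfur groups in this setting. Nothing available here bears on why the fluoro group has this effect.

From the compounds shown here alone, it remains open whether a different group at the same position, such as chloro, methyl or methoxy, would match the fluoro group or move the number further in either direction. Going by these compounds alone, it is also open whether the two sulfur groups would still match when paired with the 4-fluorobenzyl group, as the only direct comparison of them here carries the 2,4-difluorobenzyl group.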